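Restoring a tetrazole on the biaryl of compound 2

The source may hold more compounds than are shown below. What is called first, only, known or untested is meant among the compounds shown, and "the series" means these compounds.

In a functional assay (Pituitary gland cell) with Rattus norvegicus as the target (a lower number here means that less compound is needed, a higher number that more compound is needed for the effect), compound 2 `CC(C)(N)CC(=O)N[C@@H]1CCc2ccccc2N(Cc2ccc(-c3ccccc3S(=O)(=O)NC(C)(C)C)cc2)C1=O` gives 4 uM, the higher of the two numbers shown, while compound 1 `CC(O)Cn1nnnc1-c1ccccc1-c1ccc(CN2C(=O)[C@H](NC(=O)CC(C)(C)N)CCc3ccccc32)cc1` gives 0.05 uM. Compound 3 `CC(C)(N)CC(=O)N[C@@H]1CCc2ccccc2N(Cc2ccc(-c3ccccc3-c3nnnn3Cc3ccccc3)cc2)C1=O` carries 1-benzyl-1H-tetrazol-5-yl in place of (tert-butyl)sulfamoyl on an aromatic carbon. Among the measured compounds shown here, the one step that bears on this is an 80-fold higher number from compound 1 to compound 2 (1.90 log units; beyond the scatter), where the tetrazole gave way to the sulfonamide; compound 3 reverses that exchange, though with a benzyl rather than a hydroxypropyl on the tetrazole, so a large move toward a lower number is expected, a 40-fold lower number from compound 2 to compound 3 (1.60 log units; beyond the scatter). Compound 3 is therefore estimated at 0.1 uM, with a range from 0.03 uM to 0.5 uM.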

Compound 3, concentration for half-maximal effect: 0.7 uM
For compound 3 the middle estimate is 7.0-fold (0.85 log units) below the measured one; measured number outside the range, above it.
By their numbers in this assay, from the lowest: compound 1; then compound 3; then compound 2.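

In this assay, 1-benzyl-1H-tetrazol-5-yl recovers only part of what (tert-butyl)sulfamoyl lost, with a 5.7-fold lower number from compound 2 to compound 3 (0.76 log units; beyond the scatter) set against an 80-fold higher number from compound 1 to compound 2 (1.90 log units; beyond the scatter) in the other direction. The tetrazole alone therefore does not settle the number: the chain on its aromatic nitrogen also counts, since phenyl in place of 1-hydroxyethyl gives a 14-fold higher number from compound 1 to compound 3 (1.15 log units; beyond the scatter) on that chain. Nothing measured here accounts for this difference. Still open, from the compounds shown here alone, is how a shorter chain such as methyl, or an amine or carboxylic acid on that chain, would compare with compound 1.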